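Chalcone series: cyclohexyl to 4-fluorophenyl at the alkene

The source may report more compounds than this note shows. Statements on the series, on what has been measured and on what is new or still open speak of the compounds shown alone.

Measured so far in a functional assay on SW1573 cells (Homo sapiens) for inhibition, read by sulforhodamine B assay, with a stated time of 48 h; on this read-out higher numbers stand for weaker inhibition of growth and lower numbers for stronger inhibition of growth:
- compound 1 `O=C(/C=C/c1ccc(Cl)cc1Cl)c1ccccc1`: 12000 nM
- compound 2 `O=C(/C(=C/C1CCCCC1)CCl)c1ccccc1`: 23000 nM
- compound 3 `CC(=O)OC/C(=C\C1CCCCC1)C(=O)c1ccccc1`: 19000 nM

Compound 3 sits second highest of the three numbers. Among the compounds with values here, its nearest neighbour is compound 2, and the only single-point step available, a 1.2-fold lower number from compound 2 to compound 3 (0.08 log units; within the scatter), is small and within the scatter. Compound 1 is the furthest from compound 3, yet that gap too stays within the scatter, so the three measured compounds are not separated from one another on this read-out.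

Compound 4 `CC(=O)OC/C(=C\c1ccc(F)cc1)C(=O)c1ccccc1` is not yet measured. It differs from compound 3 in one place: 4-fluorophenyl in place of cyclohexyl on a double-bonded chain carbon bound to a double-bonded chain carbon. Within the data shown here, no measured step covers this exchange. The step from compound 2 to compound 3 concerns the saturated chain carbon and not the double-bonded one, so it does not bear on it directly. Among the measured compounds shown here, the only hint is that compound 1, which also carries an aromatic ring on the double-bonded chain carbon but lacks the acetoxymethyl branch, gives a number within the scatter of compound 3.

On that basis the expected step of a 1.5-fold lower number from compound 3 to compound 4 (0.16 log units; within the scatter) is small, with perhaps a slight lean to a lower number in this assay. Compound 4 is therefore estimated at 13000 nM, with a range from 5000 nM to 35000 nM.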

Compound 4, concentration for 50% growth inhibition: 4200 nM
Compound 4: middle estimate off by 3.1-fold (0.49 log units), on the high side; measured number outside the range, below it.
By their numbers in this assay, from the lowest: compound 4; then compounds 1, 3 and 2 (each within the scatter of the next).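

In this assay, within the data shown here, the exchange of cyclohexyl for 4-fluorophenyl on a double-bonded chain carbon bound to a double-bonded chain carbon gives a 4.5-fold lower number from compound 3 to compound 4 (0.66 log units; beyond the scatter) and is the first single-place step to lie beyond the scatter, though only modestly. The earlier step at the saturated chain carbon, a 1.2-fold lower number from compound 2 to compound 3 (0.08 log units; within the scatter) in size, did not separate its pair, so this double-bonded chain carbon is the only place shown so far where one exchange moves the number beyond the scatter. No measurement in hand accounts for this step, so it stands as an observation on a single pair of compounds.

The compounds shown leave open whether the shift follows from replacing the saturated ring with an aromatic ring or depends on the fluorine, which a plain phenyl group at this place would help to separate from the 4-fluorophenyl result. They also leave open whether the same exchange gives a step of similar size with chloro on the saturated chain carbon, or with an amine or a hydroxyl group in place of the acetoxy group.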